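Notes on compound 3: methyl in place of methoxy

The source may report more compounds than this note shows. Statements on the series, on what has been measured and on what is new or still open speak of the compounds shown alone.

Compound 1 `COc1ccccc1-c1cnc(NC(=O)c2ccc(F)cc2)n1C` in a toxicity assay on THP-1 cells (Homo sapiens) for inhibition (on this read-out higher numbers stand for lower toxicity in this test and lower numbers for higher toxicity in this test), gives > 100000 nM, a limit of the assay.
Compound 2 `COc1cccc(-c2cnc(NC(=O)c3ccc(F)cc3)n2C)c1` in this assay gives > 100000 nM, also a limit of the assay.

Compound 2 thus stands at the assay limit, and the step that the two limits leave unreadable from compound 1 to compound 2 cannot be read since both values sit at the limit of > 100000 nM in this assay, at which 2 of the 2 values shown sit. Compound 3 `Cc1cccc(-c2cnc(NC(=O)c3ccc(F)cc3)n2C)c1` differs from compound 2 by methyl in place of methoxy on an aromatic carbon. Among the measured compounds shown here, no measured step bears directly on this change. Given that compound 2 sits at the limit of > 100000 nM in this assay, at which 2 of the 2 values shown sit, compound 3 is expected to remain at the limit as well, with a step that the limit leaves unreadable from compound 2 to compound 3 of none beyond the scatter. The estimate for compound 3 in this assay is 150000 nM, between 60000 nM and 400000 nM.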

Compound 3, half-maximal cytotoxic concentration: > 100000 nM
Compound 3: a limit, no number (the forecaster's own chance of this, stated with the estimate: 80%); the middle value does not contradict the limit.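

Compound 3 gives > 100000 nM in this assay, a limit of the assay. Steps from compound 1 and compound 2 to compound 3 therefore cannot be read: the limit of > 100000 nM in this assay, at which 3 of the 3 values shown sit.

The compounds shown leave open whether 2-methoxyphenyl, 3-methoxyphenyl and 3-methylphenyl differ at all in this assay.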